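Pyridin-4-yl in Place of Phenyl: Outlook for Compound 4

A few compounds are considered here, and "the series" means these few. Any claim that something is new, unique, unknown or untested is made for them only; others in the source may bear on it.

Measured in an assay on isolated protein for inhibition of 3-hydroxy-3-methylglutaryl-coenzyme A reductase (Homo sapiens); on this read-out lower numbers stand for stronger inhibition and higher numbers for weaker inhibition:
compound 1, `Cc1cc(F)ccc1-c1c(-c2ccc(F)cc2)nc(C(C)C)n1/C=C/[C@@H](O)C[C@@H](O)CC(=O)O`, gives 8.4 nM
compound 2, `CNc1cccc(-c2nc(C(C)C)n(/C=C/[C@@H](O)C[C@@H](O)CC(=O)O)c2-c2ccc(F)cc2)c1`, gives 8.52 nM
compound 3, `CC(C)c1cc(-c2ccccc2)c(-c2ccc(F)cc2)n1/C=C/[C@@H](O)C[C@@H](O)CC(=O)O`, gives 8.7 nM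

All three numbers in this assay fall within the usual scatter of one another, so compound 3 is neither set apart from compound 1 nor from compound 2; the set is flat. No pair of these compounds differs in only one place, so no single structural step has been measured here.

Compound 4, `CC(C)c1cc(-c2ccncc2)c(-c2ccc(F)cc2)n1/C=C/[C@@H](O)C[C@@H](O)CC(=O)O`, is not yet measured. It differs from compound 3 by pyridin-4-yl in place of phenyl on an aromatic carbon. Among the measured compounds shown here, with no measured step of this kind to lean on, the expected change in this assay from compound 3 is small and without a firm direction; for compound 4 the expected step is a 1.3-fold higher number from compound 3 to compound 4 (0.10 log units; within the scatter). Compound 4 is estimated at 11 nM, with a range from 4 nM to 30 nM.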

Compound 4, half-maximal inhibitory concentration: 8.3 nM
Estimate against measurement, compound 4: 1.3-fold (0.12 log units) above; low and high end bracket the measured number.
By their numbers in this assay, from the lowest: compounds 4, 1, 2 and 3 (each within the scatter of the next).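

In this assay, among the compounds shown here, the exchange of phenyl for pyridin-4-yl gives the first single-place step, a 1.0-fold lower number from compound 3 to compound 4 (0.02 log units; within the scatter), on the aromatic carbon next to the ring atom that bears a 4-fluorophenyl group. At this position, a ring nitrogen and one added hydrogen-bond acceptor therefore leave the number within the scatter. No available evidence explains this outcome. Open, from the compounds shown here alone, is whether pyridin-3-yl gives the same result here. Also open, going by these compounds, is how a non-aromatic group, such as an amine, a carboxylic acid or a longer alkyl chain, behaves at this carbon.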